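Replacing the Aryl Group on a Urea Analogue

This account rests on a few compounds, and the source may have more. Where it says the series, first, only, none or still open, it means among the compounds named here.

Compound 3 `COC(=O)/C=C/c1cccc(N(Cc2ccc(-c3cccc(C)c3)cc2)C(=O)NC(C)C)c1` gives 1330 nM in an assay on isolated protein with Bile acid receptor (Homo sapiens) as the target (a lower number here means that less compound is needed, a higher number that more compound is needed for the effect), the highest of the three numbers measured; compound 2 `COC(=O)/C=C/c1cccc(N(Cc2ccc(-c3c(OC)cccc3OC)cc2)C(=O)C(C)C)c1` gives 95 nM and compound 1 `COC(=O)/C=C/c1cccc(N(Cc2ccc(-c3c(OC)cccc3OC)cc2)C(=O)C2CCCCC2)c1` gives 77 nM. Compound 4 `COC(=O)/C=C/c1cccc(N(Cc2ccc(-c3c(OC)cccc3OC)cc2)C(=O)NC(C)C)c1` differs from compound 3 in one place: 2,6-dimethoxyphenyl in place of 3-methylphenyl on an aromatic carbon. Among the compounds with values here, no measured step isolates this change. Within the data shown here, the only step available, a 1.2-fold higher number from compound 1 to compound 2 (0.09 log units; within the scatter), concerns the group on the carbonyl carbon and stays within the scatter. Compound 2 carries the entering group together with an amide instead of a urea, and its number is well below that of compound 3, but two changes separate those two compounds. A lower number is therefore expected for compound 4, with an expected step of a 5.3-fold lower number from compound 3 to compound 4 (0.73 log units; beyond the scatter), estimated at 250 nM within a range of 70 nM to 900 nM.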

Compound 4, half-maximal effective concentration: 561 nM
Compound 4: middle estimate off by 2.2-fold (0.35 log units), on the low side; low and high end bracket the measured number.
By their numbers in this assay, from the lowest: compounds 1 and 2 (each within the scatter of the next); then compound 4; then compound 3.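

In this assay the aryl change can now be read on its own, as a 2.4-fold lower number from compound 3 to compound 4 (0.37 log units; beyond the scatter) for 2,6-dimethoxyphenyl in place of 3-methylphenyl on the urea. With that aryl group held fixed, the group on the carbonyl carbon also proves to matter, with a 5.9-fold higher number from compound 2 to compound 4 (0.77 log units; beyond the scatter) for isopropylamino in place of isopropyl and a 7.3-fold higher number from compound 1 to compound 4 (0.86 log units; beyond the scatter) for isopropylamino in place of cyclohexyl, although the earlier step between the two amides stayed within the scatter. No measurement here gives a reason for these steps. Going by these compounds, it remains open whether the aryl change would act the same way on the amides, and whether a hydroxyl group or a pyridine ring at this position would lower the number further.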